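From 4-chlorophenyl to 3-nitrophenyl: a small expected step

The compounds below may be only part of what the source reports. "The series", "measured", "known", "first", "only" and "open" are said of these compounds alone.

Compound 1 (`CCCCCCCCCCCCCCNC(=O)[C@H](CO)/N=C/c1cccc(OC)c1`) gives 31300 nM in a functional assay on cells (Homo sapiens) for cytotoxicity, read by MTT assay, with a stated time of 24 h (on this read-out higher numbers stand for weaker inhibition and lower numbers for stronger inhibition), and compound 2 (`CCCCCCCCCCCCCCNC(=O)[C@H](CO)/N=C/c1ccc(Cl)cc1`) gives 27500 nM there. Compound 2 therefore stands level with compound 1, since the step (a 1.1-fold lower number from compound 1 to compound 2 (0.06 log units; within the scatter)) stays within the scatter. Compound 3 (`CCCCCCCCCCCCCCNC(=O)[C@H](CO)/N=C/c1cccc([N+](=O)[O-])c1`) carries 3-nitrophenyl in place of 4-chlorophenyl on a carbon with a double bond to nitrogen. That single measured step, made at the same place, is all that bears on this change, so no step beyond the scatter is expected in this assay here. The expected step (a 1.0-fold lower number from compound 2 to compound 3 (0.01 log units; within the scatter)) is correspondingly small. For compound 3 the estimated value is 27000 nM with 13000 nM to 52000 nM as the expected range.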

Compound 3, half-maximal inhibitory concentration: 104000 nM
Beside the measured number, compound 3's estimate is 3.9-fold (0.59 log units) below it; the measured number lies above the stated range.
By their numbers in this assay, from the lowest: compounds 2 and 1 (each within the scatter of the next); then compound 3.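

The aromatic group on the carbon with a double bond to nitrogen looked unimportant from the first two compounds, but in this assay this place does respond, as 3-nitrophenyl weakens the result (a 3.8-fold higher number from compound 2 to compound 3 (0.58 log units; beyond the scatter)). Nitro in place of methoxy on an aromatic carbon is enough to produce a similar shift (a 3.3-fold higher number from compound 1 to compound 3 (0.52 log units; beyond the scatter)). Nothing shown here explains this shift.

From the compounds shown here alone, it remains open whether the weakening belongs to nitro alone or would also follow from an amine or a carboxylic acid on the aromatic ring.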